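Swapping the hydroxymethyl for 4-hydroxyphenyl on the core

The source may report more compounds than this note shows. Statements on the series, on what has been measured and on what is new or still open speak of the compounds shown alone.

Measured compounds:
compound 1 `OCc1cc2c(s1)CCC(NCCCc1ccccc1)CC2`, 61 nM
compound 2 `OCc1cc2c(s1)CCC(NCCCCc1ccccc1)CC2`, 84 nM
compound 3 `CN(CCCc1ccccc1)C1CCc2cc(CO)sc2CC1`, 6.4 nM

In an assay on membranes from brain for displacement of a labelled ligand from Sigma non-opioid intracellular receptor 1 (Cavia porcellus), read by scintillation counting, with a stated time of 120 min (on this read-out lower numbers stand for stronger inhibition and higher numbers for weaker inhibition), compound 1 gives 61 nM, the second highest of the three numbers. Its nearest neighbour is compound 2, where the step of a 1.4-fold higher number from compound 1 to compound 2 (0.14 log units; within the scatter) stays within the scatter. Its furthest is compound 3, where a 9.5-fold lower number from compound 1 to compound 3 (0.98 log units; beyond the scatter) goes beyond it.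

Compound 4 `Oc1ccc(-c2cc3c(s2)CCC(NCCCc2ccccc2)CC3)cc1` is not yet measured. It differs from compound 1 in one place: 4-hydroxyphenyl in place of hydroxymethyl on an aromatic carbon. Neither measured step touches this position. The step from compound 1 to compound 2 changes the chain beyond the amine, and the step from compound 1 to compound 3 changes the amine itself; both leave the hydroxymethyl group on the core untouched. So no shown step bears directly on the change to compound 4, and there is no basis for expecting a step of the size seen from compound 1 to compound 3.

On that footing, the step of a 1.5-fold lower number from compound 1 to compound 4 (0.18 log units; within the scatter) is expected to stay near the scatter, with a wide range either way. Compound 4 is therefore estimated at 40 nM in this assay, within 8 nM to 200 nM.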

Compound 4, inhibition constant: 181 nM
Estimate against measurement, compound 4: 4.5-fold (0.66 log units) below; low and high end bracket the measured number.
By their numbers in this assay, from the lowest: compound 3; then compounds 1 and 2 (each within the scatter of the next); then compound 4.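

This is the first change shown at the aromatic carbon next to the ring sulfur, and in this assay the position proves sensitive to what it carries: a 3.0-fold higher number from compound 1 to compound 4 (0.47 log units; beyond the scatter) is beyond the scatter, though modest, and the number rises, meaning weaker inhibition. The change replaces hydroxymethyl, with 2 heavy atoms and no ring, by 4-hydroxyphenyl, with 7 heavy atoms and one six-membered aromatic ring, while the hydrogen-bond donor and acceptor counts stay the same, so the step comes with no change in those counts. No measurement at hand accounts for the shift, and the step itself gives only its size and direction.

The compounds shown leave open which part of the 4-hydroxyphenyl goes with this step: a plain phenyl or a 4-methoxyphenyl here would separate the ring from its hydroxyl, and a methyl or a bare hydrogen would show what the hydroxymethyl itself adds. They also leave open whether methyl on the amine nitrogen, which gave a 9.5-fold lower number from compound 1 to compound 3 (0.98 log units; beyond the scatter) with hydroxymethyl on the core, would have a step of similar size with 4-hydroxyphenyl in that place.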